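This account rests on a few compounds, and the source may have more. Where it says the series, first, only, none or still open, it means among the compounds named here.

Three compounds share one core and differ only in the substituent on the attached benzene ring. Compound 1 `Brc1cccc2c1nnn2Cc1ccccc1` carries no substituent there, and in a functional assay on cells for positive allosteric modulation of metabotropic glutamate receptor 2 (Homo sapiens), read by fluorescence and calcium flux, with a stated time of 30 min (on this read-out higher numbers stand for an effect only at larger amounts of compound and lower numbers for an effect already at smaller amounts), compound 1 gives 80 nM. Compound 2 `Fc1cccc(Cn2nnc3c(Br)cccc32)c1` adds a fluoro group, and in this assay compound 2 gives 18 nM; compound 3 `Clc1ccc(Cn2nnc3c(Br)cccc32)cc1` adds a chloro group instead, and in this assay compound 3 gives 17 nM. Both single additions moved the number the same way: a 4.4-fold lower number from compound 1 to compound 2 (0.65 log units; beyond the scatter), and a 4.7-fold lower number from compound 1 to compound 3 (0.67 log units; beyond the scatter). Compound 3 thus shows the lowest of the three numbers, although the gap between compound 3 and compound 2 lies within the scatter, so no order between those two can be claimed.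

Compound 4 `Fc1cc(Cn2nnc3c(Br)cccc32)ccc1Cl` builds on compound 3 by a further change: fluoro in place of hydrogen on an aromatic carbon. For the measured compounds named here, no measured pair shows what a second halogen does when one is already present; the only guide is that each first halogen gave a modest step downward. A second one is expected to give at most a small step, likely within the scatter. For compound 4 in this assay the expected step is a 1.2-fold lower number from compound 3 to compound 4 (0.08 log units; within the scatter), and the estimated value for compound 4 is 14 nM, with a range from 6 nM to 35 nM.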

Compound 4, half-maximal effective concentration: 18 nM
Compound 4: middle estimate off by 1.3-fold (0.11 log units), on the low side; low and high end bracket the measured number.
By their numbers in this assay, from the lowest: compounds 3, 2 and 4 (each within the scatter of the next); then compound 1.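

In this assay, fluoro in place of hydrogen ortho to a chloro group gives a 1.1-fold higher number from compound 3 to compound 4 (0.02 log units; within the scatter), so the effect of this change depends on what the benzene ring already carries: the same change on two cores in this assay, a 4.4-fold lower number (0.65 log units; beyond the scatter) from compound 1 to compound 2 and a 1.1-fold higher number (0.02 log units; within the scatter) from compound 3 to compound 4, 4.7-fold (0.67 log units) apart, beyond the scatter of two such steps. The same holds for chloro in place of hydrogen, which gives no change at the digits printed from compound 2 to compound 4 (within the scatter) once a fluoro group is present: the same change on two cores in this assay, a 4.7-fold lower number (0.67 log units; beyond the scatter) from compound 1 to compound 3 and no change at the digits printed (within the scatter) from compound 2 to compound 4, 4.7-fold (0.67 log units) apart, beyond the scatter of two such steps. Across these four compounds, a first halogen on the ring lowers the number beyond the scatter, whereas a second one leaves it within the scatter, so the two single steps do not add up.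

Whether this position responds only weakly to any further group, or only to a second halogen, stays open, since the compounds shown carry only fluoro and chloro groups on this ring. An amine, a carboxylic acid or a longer chain ortho to a chloro group could show whether the number can move again from here, in either direction.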